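The compounds below may be only part of what the source reports. "The series", "measured", "known", "first", "only" and "open" are said of these compounds alone.

Measured so far:
Compound 1 `O=C(Nc1ccc(-c2noc(-c3cccc(NS(=O)(=O)c4ccc(C(F)(F)F)cc4)c3)n2)c(Cl)c1)c1cccnc1`: > 10000 nM
Compound 2 `O=C(Nc1ccc(-c2noc(-c3cccc(NS(=O)(=O)c4ccc(NC(=O)N5CCCC5)cc4)c3)n2)c(Cl)c1)c1cccnc1`: 5800 nM

In a functional assay on MDA-MB-231 cells (Homo sapiens) for antiproliferative activity, read by MTT assay, with a stated time of 72 h (on this read-out lower numbers stand for stronger inhibition and higher numbers for weaker inhibition), compound 1 gives only a limit, > 10000 nM. For the measured compounds named here, compound 2 gives 5800 nM in this assay, and it is the only compound with an actual number. Going by the values given here, the one measured step, an at least 1.7-fold lower number from compound 1 to compound 2 (0.23 log units; that floor lies within the scatter), is known only as a floor because of the limit of > 10000 nM in this assay, at which 1 of the 2 values shown sits. Compound 3 `O=C(Nc1ccc(-c2noc(-c3cccc(NS(=O)(=O)c4ccc(NC(=O)N5CCCCC5)cc4)c3)n2)c(Cl)c1)c1cccnc1` differs from compound 2 by piperidin-1-yl in place of pyrrolidin-1-yl on a carbonyl carbon. Among the compounds with values here, the measured step changes a different group on the sulfonamide side and says nothing about ring size here, so no step bears directly on this change. Compound 3 is therefore expected to sit close to compound 2, with a step of no change at the digits printed from compound 2 to compound 3 (within the scatter) in this assay, none beyond the scatter. The estimate for compound 3 is 5800 nM, ranging from 2500 nM to 13000 nM.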

Compound 3, half-maximal inhibitory concentration: > 10000 nM
Compound 3: only a limit was reported; the forecaster's own chance of this, stated with the estimate: 25%; at least 1.7-fold (0.23 log units) between middle value and limit.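

Replacing the five-membered pyrrolidin-1-yl ring with the six-membered piperidin-1-yl ring on the carbonyl carbon gives the first view of how this ring can be varied, and in this assay compound 3 gives only a limit, > 10000 nM. The step is an at least 1.7-fold higher number from compound 2 to compound 3 (0.23 log units; that floor lies within the scatter), so these values do not establish a real loss of activity with the larger ring. Its true size remains unknown, and the steps that end at a limit offer no more than a floor or, where both values are limits, cannot be read, because so many values sit at the same ceiling: the limit of > 10000 nM in this assay, at which 2 of the 3 values shown sit.

With only compound 2 giving an actual number, no trend in ring size can be drawn. As far as these compounds go, it remains open what morpholine or an open-chain dimethylamino group would give in place of pyrrolidin-1-yl on that carbonyl carbon.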